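The source may hold more compounds than are shown below. What is called first, only, known or untested is meant among the compounds shown, and "the series" means these compounds.

Two small amides, each carrying a hydroxy group, a carbonyl and an ester, were tested in an ADME assay on HEK293 cells (Homo sapiens) for inhibition, read by CellTiter-Glo, with a stated time of 96 h, tested at 100 uM; on this read-out lower numbers stand for less inhibition and higher numbers for more inhibition at the one concentration tested (going by the name of the read-out). Compound 1 `COC(=O)/C=C/NC(=O)[C@@H](O)C(C)(C)CO` gives -2% in this assay. Compound 2 `CC(C)(C)OC(=O)/C=C/NC(=O)[C@H](O)C(C)(C)CO` gives -1% in this assay, which places it at the top of the two numbers, though its gap to compound 1 lies within the scatter. Compound 3 `COC(=O)/C=C/NC(=O)[C@H](O)C(C)(C)CO` has not yet been measured; it differs from compound 2 by methyl in place of tert-butyl on an oxygen next to a carbonyl group. Within the data shown here, no step between measured compounds exists here. Because compound 1 gives -2% and compound 2 gives -1%, the expected step is a number 1 percentage points higher from compound 2 to compound 3 (within the scatter), none beyond the scatter. Compound 3 is expected to give 0%, in the range -10% to 10%.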

Compound 3, a percentage reported as inhibition, at one concentration (the size of the read-out at that concentration, not a potency): 0%
For compound 3 middle estimate and measured number coincide at the digits printed; the range from low to high includes it.
By their numbers in this assay, from the lowest: compounds 1, 2 and 3 (each within the scatter of the next).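

In this assay, among these compounds, methyl in place of tert-butyl on an oxygen next to a carbonyl group gives a number 1 percentage points higher from compound 2 to compound 3 (within the scatter), so this change, seen alone for the first time, shows no effect beyond the scatter at this position. The drawn configuration at the saturated chain carbon also gives only a number 2 percentage points higher from compound 1 to compound 3 (within the scatter) here. That comparison isolates a single stereocentre, which compounds 1 and 2 could not do, and it rests on one point: the fact that compounds 1 and 3 differ only in the configuration as drawn.

Going by these compounds, whether a carboxylic acid in place of the ester, or a longer chain on that oxygen, would read differently stays open.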